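Chloromethyl on the acetyl: a second instance

This account rests on a few compounds, and the source may have more. Where it says the series, first, only, none or still open, it means among the compounds named here.

Compound 1 `CC(=O)N1N=C(c2ccc(N3CCN(C)CC3)cc2)CC1c1ccc(N(C)C)cc1` is the reference point of this small set. In a functional assay on NCI-H1975 cells (Homo sapiens) for inhibition, read by sulforhodamine B assay, tested at 10 uM (a higher number here means more inhibition at the concentration tested (going by the name of the read-out), a lower number less inhibition), compound 1 gives -1.9%. Compound 2 `CN1CCN(c2ccc(C3=NN(C(=O)CCCl)C(c4ccc(N(C)C)cc4)C3)cc2)CC1` carries chloromethyl in place of hydrogen on a saturated chain carbon bound to a carbonyl carbon, and this change is measured as a number 1.7 percentage points higher from compound 1 to compound 2 (within the scatter). In this assay compound 2 gives -0.2%. Compound 3 `CC(=O)N1N=C(c2ccc(-n3cncn3)cc2)CC1c1ccc(N(C)C)cc1` differs from compound 1 by 1H-1,2,4-triazol-1-yl in place of 4-methylpiperazin-1-yl on an aromatic carbon, a change measured as a number 1.6 percentage points higher from compound 1 to compound 3 (within the scatter), and in this assay compound 3 gives -0.3%. The three numbers all sit within the scatter of one another, so no ordering among them is supported, and none of the three shows inhibition at the concentration tested.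

Compound 4 `CN(C)c1ccc(C2CC(c3ccc(-n4cncn4)cc3)=NN2C(=O)CCCl)cc1` is not yet measured. It differs from compound 3 by chloromethyl in place of hydrogen on a saturated chain carbon bound to a carbonyl carbon, which is the same change that takes compound 1 to compound 2, placed on the same site: both place descriptions read, word for word, on a saturated chain carbon bound to a carbonyl carbon. The cores of the two pairs differ by 1H-1,2,4-triazol-1-yl in place of 4-methylpiperazin-1-yl on an aromatic carbon.

Among the compounds with values here, the expected step is a number 0.3 percentage points higher from compound 3 to compound 4 (within the scatter), resting on the single measured instance of the change, a number 1.7 percentage points higher from compound 1 to compound 2 (within the scatter), which lay within the scatter. Compound 4 is therefore expected to give 0% in this assay. For compound 4 the estimate spans -10% to 10%, since all three measured numbers cluster near zero inhibition.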

Compound 4, a percentage reported as inhibition, at one concentration (the size of the read-out at that concentration, not a potency): -0.7%
Compound 4: the middle estimate sits 0.7 percentage points above what was measured; measured number inside the range.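

In this assay the chloromethyl change on the second core gives a number 0.4 percentage points lower from compound 3 to compound 4 (within the scatter), and the two instances of this change do not differ: the same change on two cores in this assay, a number 1.7 percentage points higher (within the scatter) from compound 1 to compound 2 and a number 0.4 percentage points lower (within the scatter) from compound 3 to compound 4, 2.1 percentage points apart, within the scatter of two such steps

The other change, 1H-1,2,4-triazol-1-yl in place of 4-methylpiperazin-1-yl on an aromatic carbon, gives a number 0.5 percentage points lower from compound 2 to compound 4 (within the scatter) when read with the chloromethyl in place, and it too does not differ between its two instances: the same change on two cores in this assay, a number 1.6 percentage points higher (within the scatter) from compound 1 to compound 3 and a number 0.5 percentage points lower (within the scatter) from compound 2 to compound 4, 2.1 percentage points apart, within the scatter of two such steps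

Within the data shown here, this shows that on these two cores neither change moves the number out of the scatter, and that all four compounds remain near zero inhibition at the single concentration tested, but it does not show that a step of real size would carry from one core to the other, since every step compared here is within the scatter and the agreement is only one between steps that cannot be told from no change.

The compounds shown leave open whether another group on the acyl chain, such as a terminal amine in place of the chlorine or a longer chain, would lift the read-out clear of zero. Also open, on these data alone, is whether a carboxylic acid on that aromatic carbon, in place of 4-methylpiperazin-1-yl or 1H-1,2,4-triazol-1-yl, would do so, and only such a compound could give a step large enough to test transfer between the cores.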